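Chloro in place of methyl: from compound 3 to compound 4

The source may hold more compounds than are shown below. What is called first, only, known or untested is meant among the compounds shown, and "the series" means these compounds.

Values so far in a functional assay on HepG2 cells (Homo sapiens) for cytotoxicity, read by MTT assay, with a stated time of 24 h; on this read-out higher numbers stand for weaker inhibition and lower numbers for stronger inhibition
compound 1 `CN1C/C(=C\c2ccc(C#N)cc2)C(=O)/C(=C/c2cccnc2)C1` gives 12700 nM
compound 2 `Cc1ccc(S(=O)(=O)N2C/C(=C\c3cccnc3)C(=O)/C(=C/c3ccccc3F)C2)cc1` gives 4200 nM
compound 3 `Cc1ccc(S(=O)(=O)N2C/C(=C\c3ccncc3)C(=O)/C(=C/c3ccccc3F)C2)cc1` gives 9700 nM

Compound 3 at 9700 nM lies within the scatter of compound 1 and gives a higher number than compound 2. Compound 4 `O=C1/C(=C/c2ccncc2)CN(S(=O)(=O)c2ccc(Cl)cc2)C/C1=C\c1ccccc1F` carries chloro in place of methyl on an aromatic carbon and so turns 4-methylphenyl into 4-chlorophenyl. Among the compounds with values here, no measured step covers this change. Within the data shown here, the only step available a 2.3-fold higher number from compound 2 to compound 3 (0.36 log units; beyond the scatter) is modest and concerns pyridin-4-yl in place of pyridin-3-yl, so it bears only on how far these numbers can move. The expected step is a 1.2-fold lower number from compound 3 to compound 4 (0.08 log units; within the scatter) and nothing beyond the scatter is expected. In this assay compound 4 is estimated at 8000 nM with 3800 nM to 16000 nM as the expected range.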

Compound 4, half-maximal inhibitory concentration: 5300 nM
Compound 4: the middle estimate sits 1.5-fold (0.18 log units) above what was measured; measured number inside the range.
By their numbers in this assay, from the lowest: compounds 2, 4, 3 and 1 (each within the scatter of the next, the first and the last beyond it).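

Compound 2 and compound 3 both carry 4-methylphenyl, so only compound 4 speaks to this aromatic carbon, para to a large group. In this assay chloro in place of methyl gives a 1.8-fold lower number from compound 3 to compound 4 (0.26 log units; within the scatter), so this exchange stays inside the usual scatter. Nothing available here accounts for the step.

The compounds shown leave open whether a methoxy group or an amine on that aromatic carbon would reach beyond the scatter. They also leave open how chloro in place of methyl reads with pyridin-3-yl on the chain.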